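Adding a Second Chlorine: Expected Cytotoxicity

This account rests on a few compounds, and the source may have more. Where it says the series, first, only, none or still open, it means among the compounds named here.

Compound 1 `CCC1(Cc2ccccc2)OS(=O)(=O)C=C1OCC(=O)OC` and compound 2 `CCC1(Cc2ccccc2)OS(=O)(=O)C=C1OCc1ccc(Cl)cc1` share one core. In an ADME assay on HEL cells (Homo sapiens) for cytotoxicity, with a stated time of 3 days (on this read-out higher numbers stand for lower toxicity in this test and lower numbers for higher toxicity in this test), compound 1 gives only a limit, > 200000 nM. In this assay compound 2 likewise gives only a limit, > 200000 nM. The step that the two limits leave unreadable from compound 1 to compound 2 therefore cannot be read, as both values sit at the limit of > 200000 nM in this assay, at which 2 of the 2 values shown sit. Compound 3 `CCC1(Cc2ccccc2)OS(=O)(=O)C=C1OCc1ccc(Cl)c(Cl)c1` differs from compound 2 by chloro in place of hydrogen on an aromatic carbon. Going by the values given here, no measured step shows a readable size, so nothing argues for a change beyond the scatter, and compound 3 is expected to give 200000 nM, between 100000 nM and 400000 nM, most likely again reported as a limit. The step of a number no higher from compound 2 to compound 3 (the limit leaves the size open) is thus expected to be negligible.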

Compound 3, half-maximal cytotoxic concentration: 36700 nM
Compound 3: middle estimate off by 5.4-fold (0.74 log units), on the high side; measured number outside the range, below it.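

In this assay, chloro in place of hydrogen on an aromatic carbon, ortho to the existing chloro group, gives an at least 5.4-fold lower number from compound 2 to compound 3 (0.73 log units; beyond the scatter), so a lower number here means higher toxicity in this test and this position does affect the read-out. The wider change to 3,4-dichlorophenyl in place of methoxycarbonyl gives an at least 5.4-fold lower number from compound 1 to compound 3 (0.73 log units; beyond the scatter). The earlier step cannot be read, as both its values are limits: the limit of > 200000 nM in this assay, at which 2 of the 3 values shown sit.

On these data alone, whether bromo, methyl or an amine on this same carbon would also lower the number stays open. As far as these compounds go, the full size of the step stays open too: compound 2 has only a limit.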